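This account rests on a few compounds, and the source may have more. Where it says the series, first, only, none or still open, it means among the compounds named here.

Among the measured compounds shown here, in a functional assay on A549 cells (Homo sapiens) for antiproliferative activity, read by sulforhodamine B assay, with a stated time of 3 days (on this read-out higher numbers stand for weaker inhibition of growth and lower numbers for stronger inhibition of growth), three compounds sharing one core have numbers so far. Compound 1 (`O=C(Nc1nccs1)c1cccc(Nc2ncc(F)c(Nc3ccc(F)cc3)n2)c1`) gives > 10000 nM as its result, which is a limit of the assay and not a number. Compound 2 (`O=C(Nc1cccc(Nc2ncc(F)c(Nc3ccc(F)cc3)n2)c1)c1cnccn1`) gives 10300 nM as its result. Compound 3 (`COCC(=O)Nc1cccc(Nc2ncc(F)c(Nc3ccc(F)cc3)n2)c1`) gives 2050 nM as the lowest number among them, so it inhibits growth more strongly than the other two.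

Compound 4 (`Cn1ccnc1NC(=O)c1cccc(Nc2ncc(F)c(Nc3ccc(F)cc3)n2)c1`) has not yet been measured. Its difference from compound 3 is (1-methyl-1H-imidazol-2-yl)carbamoyl in place of ((methoxymethyl)carbonyl)amino on an aromatic carbon and the change lies on an aromatic carbon of a six-membered aromatic ring of carbon only, meta to a large group. In words, (1-methyl-1H-imidazol-2-yl)carbamoyl takes the place of ((methoxymethyl)carbonyl)amino.

The closest guide is compound 1, which also carries a carbamoyl group bearing a five-membered aromatic ring, and an at least 4.8-fold lower number from compound 1 to compound 3 (0.68 log units; beyond the scatter) in the swap to ((methoxymethyl)carbonyl)amino. Compound 2 points the same way, with a 5.0-fold lower number from compound 2 to compound 3 (0.70 log units; beyond the scatter) on losing its pyrazin-2-yl group. Undoing such a swap should therefore raise the number by a similar amount. The estimated step is a 3.9-fold higher number from compound 3 to compound 4 (0.59 log units; beyond the scatter) and it means weaker inhibition of growth. For compound 4 the expected value is 8000 nM with an estimated range from 3000 nM to 20000 nM in this assay and the result may well arrive only as a limit.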

Compound 4, concentration for 50% growth inhibition: 10100 nM
The estimate for compound 4 lay 1.3-fold (0.10 log units) below the measured number; the range from low to high includes it.
By their numbers in this assay, from the lowest: compound 3; then compounds 4 and 2 (each within the scatter of the next).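

In this assay, putting (1-methyl-1H-imidazol-2-yl)carbamoyl in place of ((methoxymethyl)carbonyl)amino on the aromatic carbon gives a 4.9-fold higher number from compound 3 to compound 4 (0.69 log units; beyond the scatter), the first readable size for a carbamoyl group bearing a five-membered aromatic ring at this position. The two ring-bearing groups that can be compared show no separation, with a 1.0-fold lower number from compound 2 to compound 4 (0.01 log units; within the scatter), so among compounds 2, 3 and 4 only compound 3, whose group has no ring, stands apart, and none of these three goes against that pattern. The steps from compound 1 to compound 2 and to compound 4 cannot be read, because compound 1 gives only a limit and not a number: the limit of > 10000 nM in this assay, at which 1 of the 4 values shown sits.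

With a single ring-free group shown, it stays open whether the lower number of compound 3 goes with the absence of a ring or with the methoxymethyl group itself. On these data alone, a longer ether chain, a simple acetyl group or an amine such as dimethylaminomethyl on the same carbonyl would help separate these two readings, and how far the number can fall at this position also remains unknown.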